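The source may hold more compounds than are shown below. What is called first, only, known or untested is meant among the compounds shown, and "the series" means these compounds.

Measured compounds:
- compound 1, `OC[C@H]1O[C@@H](n2cnc3c(NCc4cccc(Br)c4)ncnc32)[C@H](O)[C@@H]1O`, > 166000 nM in a functional assay on B16 cells (Mus musculus) for antiproliferative activity, with a stated time of 72 h; on this read-out higher numbers stand for weaker inhibition and lower numbers for stronger inhibition
- compound 2, `COc1ccccc1CNc1ncnc2c1ncn2[C@@H]1O[C@H](CO)[C@@H](O)[C@H]1O`, > 166000 nM in this assay
- compound 3, `COc1cc(CNc2ncnc3c2ncn3[C@@H]2O[C@H](CO)[C@@H](O)[C@H]2O)cc(OC)c1O`, "not determined" (no result reported) in this assay

The value of compound 1 in this assay is a limit of the assay and not a number. The value of compound 2 in this assay is likewise only a limit. Compound 3 has no result in this assay. The step that the two limits leave unreadable from compound 1 to compound 2, 2-methoxyphenyl in place of 3-bromophenyl on a saturated chain carbon bound to a nitrogen on an aromatic ring, therefore cannot be read, because of the limit of > 166000 nM in this assay, at which 2 of the 3 values shown sit.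

Compound 4, `Cc1cccc(CNc2ncnc3c2ncn3[C@@H]2O[C@H](CO)[C@@H](O)[C@H]2O)c1O`, is not yet measured. It differs from compound 2 by 2-hydroxy-3-methylphenyl in place of 2-methoxyphenyl on a saturated chain carbon bound to a nitrogen on an aromatic ring. The two compounds hold the same atoms joined differently. Within the data shown here, the only measured step, the one from compound 1 to compound 2, gives no size to lean on, and compound 2 itself stands only at a limit. The account therefore expects no shift beyond the scatter and expects compound 4 to remain near the same limit, with the step that the limit leaves unreadable from compound 2 to compound 4 expected to be small. Compound 4 is estimated at 200000 nM, between 80000 nM and 500000 nM.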

Compound 4, half-maximal inhibitory concentration: > 166000 nM
Compound 4: a limit, no number; the forecaster's own chance of this, stated with the estimate: 80%; the middle value is on the limit's open side.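

Compound 4 gives > 166000 nM in this assay, which is a limit and not a number. No new step can be read between compound 4 and compound 1 or compound 2: the limit of > 166000 nM in this assay, at which 3 of the 4 values shown sit.

The compounds shown leave open whether any group at this place on the saturated chain carbon gives a measurable value in this assay.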